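The source may hold more compounds than are shown below. What is called first, only, known or untested is meant among the compounds shown, and "the series" means these compounds.

Of the compounds shown here, three sharing one core have been measured in an assay on HEK293 cells for inhibition of neurogenic locus notch homolog protein 1 (Homo sapiens), read by a luciferase reporter and resazurin assay, with a stated time of 16 h; on this read-out lower numbers stand for stronger inhibition and higher numbers for weaker inhibition. Compound 1 `CC1=C(C(=O)OC2CCCCC2)C(c2ccc3c(c2)OCCO3)C2=C(CC(C)(C)CC2=O)N1` gives 12300 nM in this assay. Compound 2 `CC1=C(C(=O)OCCC2CCN(C(=O)OC(C)(C)C)CC2)C(c2cccc(Br)c2)C2=C(CC(C)(C)CC2=O)N1` gives 2950 nM in this assay. Compound 3 `CC1=C(C(=O)OCC2CCN(C(=O)OC(C)(C)C)CC2)C(c2cccc([N+](=O)[O-])c2)C2=C(CC(C)(C)CC2=O)N1` stands apart: in this assay it reaches only a limit of the measurement, > 10000 nM, so no number is known for it, only that it lies at the weak end of what the assay can report, as described by the limit of > 10000 nM in this assay, at which 1 of the 3 values shown sits. On the numbers shown, compound 3 is therefore the one with the least resolved value, and its standing can only be read as weaker than compound 2 and at or beyond compound 1.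

Compound 4 `CC1=C(C(=O)OCC2CCN(C(=O)OC(C)(C)C)CC2)C(c2cccc(C(F)(F)F)c2)C2=C(CC(C)(C)CC2=O)N1` has not yet been measured. It differs from compound 3 in a single place: trifluoromethyl in place of nitro on an aromatic carbon. Among the compounds with values here, no measured pair shows this same change, so the size of the step can only be expected, not read off. The expectation is that the step from compound 3 to compound 4 in this assay, an at least 1.6-fold lower number from compound 3 to compound 4 (0.22 log units; that floor lies within the scatter), is a gain in inhibition that goes beyond the usual scatter, bringing compound 4 back into the range where a number is reported. For compound 4 the estimate in this assay is 6000 nM, with a range from 1500 nM to 30000 nM.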

Compound 4, half-maximal inhibitory concentration: 760 nM
Estimate against measurement, compound 4: 7.9-fold (0.90 log units) above, and the stated range ends above it.
By their numbers in this assay, from the lowest: compound 4; then compound 2; then compound 1.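

With the rest of the molecule unchanged, trifluoromethyl in place of nitro on an aromatic carbon gives an at least 13-fold lower number from compound 3 to compound 4 (1.11 log units; beyond the scatter) in this assay and shows that this one group can move the result by a large step. The earlier compounds shown here differ from one another in more than one place, so they could not show what this position does alone. The full size of the step cannot be read, because compound 3 stands at a limit rather than at a number: the limit of > 10000 nM in this assay, at which 1 of the 4 values shown sits.

Going by these compounds, whether a chlorine, a nitrile or a methyl group at this place would match trifluoromethyl remains open. So does whether the same change would give a similar step with the ester of compound 1 or compound 2 in place of the one shared by compound 3 and compound 4.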